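Cyclopentylmethoxy to ethoxy on compound 2

The compounds below may be only part of what the source reports. "The series", "measured", "known", "first", "only" and "open" are said of these compounds alone.

In a functional assay on PC-12 cells (Rattus norvegicus) for inhibition, read by sulforhodamine B assay (on this read-out lower numbers stand for stronger inhibition and higher numbers for weaker inhibition), compound 1 `O=C1N=C(O)S/C1=C\c1ccc(OCC2CCCCC2)cc1` gives 14000 nM and compound 2 `O=C1NC(=O)C(Cc2ccc(OCC3CCCC3)cc2)S1` gives 25000 nM and compound 3 `CC(C)COc1ccc(/C=C2\SC(=O)NC2=O)cc1` gives 16000 nM with all three inside the usual scatter of one another. Compound 2 therefore stands apart from neither of the others. Compound 4 `CCOc1ccc(CC2SC(=O)NC2=O)cc1` carries methyl in place of cyclopentyl on a saturated chain carbon bound to an oxygen on an aromatic ring as its change from compound 2. Within the data shown here, no measured pair isolates such a change, so the only support is the closeness of the three values, such as compound 3 at 16000 nM in this assay series. The expected 1.2-fold higher number from compound 2 to compound 4 (0.08 log units; within the scatter) lies within the scatter, with no direction beyond it. Compound 4 is estimated at 30000 nM with an expected range of 14000 nM to 70000 nM for its measurement.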

Compound 4, half-maximal inhibitory concentration: > 100000 nM
Compound 4 gave a limit, no number; the forecaster's own chance of this, stated with the estimate: 15%; at least 3.3-fold (0.52 log units) between middle value and limit.
By their numbers in this assay, from the lowest: compounds 1, 3 and 2 (each within the scatter of the next). At a limit, above all of these: compound 4.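

Methyl in place of cyclopentyl on a saturated chain carbon bound to an oxygen on an aromatic ring gives an at least 4.0-fold higher number from compound 2 to compound 4 (0.60 log units; beyond the scatter), the only step in the series and one beyond the scatter. In this assay compound 4 gives > 100000 nM, which is a limit and not a number: the limit of > 100000 nM in this assay, at which 1 of the 4 values shown sits. The group at this place therefore matters to the read-out, which compounds 1, 2 and 3 could not show.

On these data alone, the change removes the ring and carbon count together, so the contribution of each stays open. An open-chain butyl at this place would separate the two.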